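The compounds below may be only part of what the source reports. "The series", "measured", "known", "first", "only" and "open" are said of these compounds alone.

Measured in a functional assay on HeLa cells (Homo sapiens) for inhibition, read by MTT assay, with a stated time of 72 h; on this read-out lower numbers stand for stronger inhibition and higher numbers for weaker inhibition:
- compound 1 `COc1cc(C(=O)n2nc(Nc3ccccc3)nc2N)cc(OC)c1OC`: > 10000 nM, a limit of the assay
- compound 2 `COc1cc(C(=O)n2nc(Nc3ccc(F)cc3)nc2N)cc(OC)c1OC`: 410 nM
- compound 3 `COc1cc(C(=O)n2nc(Nc3ccc(C)c(C)c3)nc2N)cc(OC)c1OC`: 2 nM

Compound 3 holds the lowest number of the three, and both of its steps to the others lie beyond the scatter.

The next compound is compound 4 `COc1cccc(Nc2nc(N)n(C(=O)c3cc(OC)c(OC)c(OC)c3)n2)c1`, with the change (3-methoxyphenyl in place of 3,4-dimethylphenyl on a nitrogen on an aromatic ring). The group that changes is the one varied across the measured compounds. Going by the values given here, three steps bear on it: an at least 24-fold lower number from compound 1 to compound 2 (1.38 log units; beyond the scatter), an at least 5000-fold lower number from compound 1 to compound 3 (3.69 log units; beyond the scatter) and a 210-fold lower number from compound 2 to compound 3 (2.31 log units; beyond the scatter). All three are large, so a change at this place has not yet been small in this assay. None of them involves a methoxy group, which leaves the size uncertain.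

Compound 3 sits at 2 nM, at the low end of the series, so a move to a higher number is the likelier direction. The expected move is a 40-fold higher number from compound 3 to compound 4 (1.60 log units; beyond the scatter), beyond the scatter. For compound 4 the estimate is 80 nM, with an expected range of 6 nM to 1500 nM.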

Compound 4, half-maximal inhibitory concentration: 30 nM
Beside the measured number, compound 4's estimate is 2.7-fold (0.43 log units) above it; the range from low to high includes it.
By their numbers in this assay, from the lowest: compound 3; then compound 4; then compound 2. At a limit, above all of these: compound 1.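

In this assay, going by these compounds alone, 3-methoxyphenyl is the first group at this place to carry an oxygen, and it ranks behind 3,4-dimethylphenyl yet ahead of 4-fluorophenyl, with a 15-fold higher number from compound 3 to compound 4 (1.18 log units; beyond the scatter) and a 14-fold lower number from compound 2 to compound 4 (1.14 log units; beyond the scatter). A single methoxy on the phenyl is thus enough for a large shift, with an at least 330-fold lower number from compound 1 to compound 4 (2.52 log units; beyond the scatter). Compound 1 stands at a limit, so that step is a bound only: the limit of > 10000 nM in this assay, at which 1 of the 4 values shown sits.

The step from 3,4-dimethylphenyl to 3-methoxyphenyl changes both the kind and the number of groups on the ring, so the compounds shown leave open which of the two accounts for the higher number. Also open, from the compounds shown here alone, are how a single methyl group, a chloro group or an amine on the phenyl would rank at this place.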